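The source may hold more compounds than are shown below. What is called first, only, known or untested is meant among the compounds shown, and "the series" means these compounds.

Compound 3 `[N-]=[N+]=Nc1cc2ccccc2oc1=O` is the smallest of the three measured compounds. In a toxicity assay on MRC5 cells (Homo sapiens) for cytotoxicity, read by MTT assay, with a stated time of 24 h (a lower number here means a stronger inhibitor, a higher number a weaker inhibitor), compound 3 gives 70200 nM. Compound 1 `COc1cccc2cc(N=[N+]=[N-])c(=O)oc12` carries one change relative to it, (methoxy in place of hydrogen on an aromatic carbon), and in this assay compound 1 gives 58700 nM. The step of a 1.2-fold lower number from compound 3 to compound 1 (0.08 log units; within the scatter) is therefore small. Compound 2 `NCCC(=O)N1Cc2ccccc2-c2nnn(-c3cc4ccccc4oc3=O)c2-c2ccccc21` has a different core; how the two cores of compound 2 and compound 3 differ is not broken down here. In this assay compound 2 gives 110000 nM, and its value and that of compound 3 lie within the usual scatter of each other.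

Compound 4 `COc1cccc2cc(-n3nnc4c3-c3ccccc3N(C(=O)CCN)Cc3ccccc3-4)c(=O)oc12` has not yet been measured. Relative to compound 2 it carries methoxy in place of hydrogen on an aromatic carbon, the same change that separates compound 1 from compound 3. Set beside the earlier step, the step from compound 2 to compound 4 is expected to be a 1.2-fold lower number from compound 2 to compound 4 (0.09 log units; within the scatter) in this assay, because a 1.2-fold lower number from compound 3 to compound 1 (0.08 log units; within the scatter) was small. For compound 4 a value of about 90000 nM is expected in this assay, with a likely range from 40000 nM to 200000 nM.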

Compound 4, half-maximal inhibitory concentration: 92800 nM
Beside the measured number, compound 4's estimate is 1.0-fold (0.01 log units) below it, within the range that was stated.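

Carried over to the second core, methoxy in place of hydrogen on an aromatic carbon gives a 1.2-fold lower number from compound 2 to compound 4 (0.07 log units; within the scatter) in this assay. The step on one core matches the step on the other: the same change on two cores in this assay, a 1.2-fold lower number (0.08 log units; within the scatter) from compound 3 to compound 1 and a 1.2-fold lower number (0.07 log units; within the scatter) from compound 2 to compound 4, 1.0-fold (0.00 log units) apart, within the scatter of two such steps. This shows that, in this assay and at this one place, the change stays within the scatter on both cores, so the small step carries from one core to the other in these two pairs; it does not show that methoxy would do the same on another aromatic carbon, on a further core or in a different assay.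

The compounds shown carry only hydrogen or methoxy at this place, so it remains open whether an amine, a fluorine atom, a hydroxyl group or a longer chain such as ethoxy would also leave the number within the scatter. Going by these compounds, it also remains open whether either core would respond to any group with a step beyond the scatter.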